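Adding a Chloro Group to the Urea Aryl Ring

The source may hold more compounds than are shown below. What is called first, only, known or untested is meant among the compounds shown, and "the series" means these compounds.

Measured so far:
compound 1 `Cc1cc(-c2ccc(NC(=O)Nc3cccc(Cl)c3)cc2)c2c(N)onc2n1` 540 nM
compound 2 `Cc1cc(-c2ccc(NC(=O)Nc3cccc(C(F)(F)F)c3)cc2)c2c(N)onc2n1` 610 nM

In a functional assay on MV4-11 cells (Homo sapiens) for antiproliferative activity, read by fluorescence, with a stated time of 72 h (on this read-out lower numbers stand for stronger inhibition and higher numbers for weaker inhibition), compound 2 gives 610 nM, the higher of the two numbers shown, though within the scatter of compound 1, as a 1.1-fold higher number from compound 1 to compound 2 (0.05 log units; within the scatter) shows. Compound 3 `Cc1cc(-c2ccc(NC(=O)Nc3ccc(Cl)c(C(F)(F)F)c3)cc2)c2c(N)onc2n1` is not yet measured; it differs from compound 2 by chloro in place of hydrogen on an aromatic carbon, the chloro entering ortho to a trifluoromethyl group and para to a large group. For the measured compounds named here, no measured step bears directly on this change: the one step at hand, a 1.1-fold higher number from compound 1 to compound 2 (0.05 log units; within the scatter), exchanged a group rather than adding one and lay within the scatter. In this assay a step no larger than the scatter is therefore expected, namely a 1.4-fold lower number from compound 2 to compound 3 (0.13 log units; within the scatter). Compound 3 is estimated at 450 nM, within 150 nM to 1400 nM.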

Compound 3, half-maximal inhibitory concentration: 340 nM
For compound 3 the middle estimate is 1.3-fold (0.12 log units) above the measured one, and the stated range covers the measured number.
By their numbers in this assay, from the lowest: compounds 3, 1 and 2 (each within the scatter of the next).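

In this assay, placing chloro on the aromatic carbon ortho to a trifluoromethyl group and para to a large group gives a 1.8-fold lower number from compound 2 to compound 3 (0.25 log units; within the scatter), so this position accepts the added atom with a step that stays within the scatter. Unlike the earlier step, which exchanged one group for another, this change adds a group to the ring. Nothing at hand accounts for this result. As far as these compounds go, whether an amine, a methoxy group or a carboxylic acid at this position would give a step beyond the scatter stays open. Also open, from the compounds shown here alone, is whether chloro here would give a like step in the absence of the trifluoromethyl group.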